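Three Analogues at the Limit and a Fourth Unmeasured

The compounds below may be only part of what the source reports. "The series", "measured", "known", "first", "only" and "open" are said of these compounds alone.

Compound 1 `Oc1ccccc1-c1cc(-c2cccc(C(F)(F)F)c2)cc(-c2ccccc2O)n1` carries a 3-(trifluoromethyl)phenyl group on the shared core. In a functional assay on T47D cells (Homo sapiens) for inhibition (on this read-out lower numbers stand for stronger inhibition and higher numbers for weaker inhibition), compound 1 reaches only the limit of the assay, > 50000 nM, which is not a number. Compound 2 `Oc1ccccc1-c1cc(-c2ccc(C(F)(F)F)cc2)cc(-c2ccccc2O)n1` has the same atoms as compound 1 joined differently, and the difference is 4-(trifluoromethyl)phenyl in place of 3-(trifluoromethyl)phenyl on an aromatic carbon. In this assay compound 2 likewise stops at the limit, > 50000 nM. Compound 3 `Oc1ccccc1-c1cc(-c2cccc(OC(F)(F)F)c2)cc(-c2ccccc2O)n1` differs from compound 1 by trifluoromethoxy in place of trifluoromethyl on an aromatic carbon. Compound 3 also gives only the limit, > 50000 nM. The step that the two limits leave unreadable from compound 1 to compound 2 and the step that the two limits leave unreadable from compound 1 to compound 3 therefore cannot be sized, which rests on (the limit of > 50000 nM in this assay, at which 3 of the 3 values shown sit).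

Compound 4 `Oc1ccccc1-c1cc(-c2ccc(OC(F)(F)F)cc2)cc(-c2ccccc2O)n1` has not been measured. It differs from compound 2 by trifluoromethoxy in place of trifluoromethyl on an aromatic carbon. This is the same kind of change as from compound 1 to compound 3, though the place differs: there the entering group sits meta to a large group, whereas in compound 4 it sits para to a large group. Within the data shown here, nothing among the three measured compounds shows a readable number, so no sized step is available to carry over. Compound 4 is expected to show 70000 nM in this assay, with a range from 20000 nM to 200000 nM, meaning an expected step that the limit leaves unreadable from compound 2 to compound 4, and this expectation rests on (the limit of > 50000 nM in this assay, at which 3 of the 3 values shown sit).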

Compound 4, half-maximal inhibitory concentration: > 50000 nM
Compound 4: no number, only a limit; the forecaster's own chance of this, stated with the estimate: 85%; the middle value does not contradict the limit.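

In this assay compound 4 gives > 50000 nM, which is a limit of the assay and not a number. No new step can be read from compound 2 to compound 4, because both stop at a limit: the limit of > 50000 nM in this assay, at which 4 of the 4 values shown sit. The compounds shown leave open whether trifluoromethoxy in place of trifluoromethyl changes inhibition at all, and what actual number any of the four compounds would give.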